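Adding One More Carbon to the Chain of Compound 2

The source may report more compounds than this note shows. Statements on the series, on what has been measured and on what is new or still open speak of the compounds shown alone.

Compound 1 `CCCCn1c(CCC)nc2cc(N)ccc21` gives 59.1% in a functional assay on the whole organism with Rattus norvegicus as the target, read by paw edema, with a stated time of 5 h, at a dose of 75 mg/kg by the oral route; a lower number here means a weaker effect, a higher number a stronger effect of the compound at the dose given
Compound 2 `CCCCCn1c(CCC)nc2cc(N)ccc21` gives 66.4% in this assay

Of the two numbers, compound 2 gives the higher one, yet the step of a number 7.3 percentage points higher from compound 1 to compound 2 (within the scatter) is within the scatter, so the two compounds cannot be separated. Compound 3 `CCCCCCn1c(CCC)nc2cc(N)ccc21` differs from compound 2 by methyl in place of hydrogen on a saturated chain carbon, five bonds along the chain from an aromatic nitrogen. Among the compounds with values here, the only step that bears on this is a number 7.3 percentage points higher from compound 1 to compound 2 (within the scatter), the same kind of change made one bond closer to the aromatic nitrogen, and it stayed within the scatter. No step beyond the scatter is therefore expected for compound 3. The change expected for compound 3 is a number 1.6 percentage points higher from compound 2 to compound 3 (within the scatter). Compound 3 is estimated to give 68%, between 55% and 80%.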

Compound 3, a percentage reported as activity, at one dose (the size of the read-out at that dose, not a potency): 69.1%
Compound 3: middle estimate off by 1.1 percentage points, on the low side, within the range that was stated.
By their numbers in this assay, from the lowest: compounds 1, 2 and 3 (each within the scatter of the next).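

In this assay, one more methyl at this place gives a number 2.7 percentage points higher from compound 2 to compound 3 (within the scatter) and so adds nothing that can be read. Even ethyl in place of hydrogen, taken as one larger change, gives a number 10 percentage points higher from compound 1 to compound 3 (within the scatter) and stays inside the usual variation, so across compounds 1, 2 and 3 chain length makes no readable difference at this dose. Nothing measured here offers an explanation for this flat result.

Going by these compounds, whether a longer chain such as decyl, or a chain ending in a carboxylic acid, would produce a step beyond the scatter remains open.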